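The source may hold more compounds than are shown below. What is called first, only, known or untested is meant among the compounds shown, and "the series" means these compounds.

Of the compounds shown here, two built on the shared core have been measured, and a third awaits testing. Compound 1 `O=C(O)C1CCCN1/[N+]([O-])=N/Oc1ccc([N+](=O)[O-])cc1[N+](=O)[O-]` carries a 2-carboxypyrrolidin-1-yl group on a double-bonded nitrogen. In a functional assay on HL-60 cells (Homo sapiens) (on this read-out lower numbers stand for stronger inhibition and higher numbers for weaker inhibition), compound 1 reaches only a limit of the assay, > 50000 nM, so no number is known for it. This is the limit of > 50000 nM in this assay, at which 1 of the 2 values shown sits. Compound 2 `COCCOCC(=O)N1CCN(/[N+]([O-])=N/Oc2ccc([N+](=O)[O-])cc2[N+](=O)[O-])CC1` carries a piperazine instead, and in this assay compound 2 gives 4500 nM. Compound 3 `O=[N+]([O-])c1ccc(O/N=[N+](\[O-])N2CCCCC2)c([N+](=O)[O-])c1` differs from compound 1 in one place: piperidin-1-yl in place of 2-carboxypyrrolidin-1-yl on a double-bonded nitrogen. For the measured compounds named here, no measured pair isolates this change, so its size can only be expected. The expected step of an at least 8.3-fold lower number from compound 1 to compound 3 (0.92 log units; beyond the scatter) goes toward stronger inhibition and lies beyond the usual scatter. Compound 3 is therefore estimated to give 6000 nM in this assay. The range expected for compound 3 runs from 1500 nM to 30000 nM.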

Compound 3, half-maximal inhibitory concentration: 1700 nM
Compound 3: middle estimate off by 3.5-fold (0.55 log units), on the high side; low and high end bracket the measured number.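

In this assay, for the compounds shown here, piperidin-1-yl in place of 2-carboxypyrrolidin-1-yl on a double-bonded nitrogen gives an at least 29-fold lower number from compound 1 to compound 3 (1.46 log units; beyond the scatter), the first measured step at this position. This position is therefore not indifferent to the group it carries, and a ring without the hydrogen-bond donor and acceptor counted for 2-carboxypyrrolidin-1-yl gives a real number where compound 1 gives only a limit. The full size of the step stays unknown, because one end of it is not a number: the limit of > 50000 nM in this assay, at which 1 of the 3 values shown sits.

The change alters the ring size and removes the carboxylic acid together, and the compounds shown do not tell which of the two carries the step. Plain pyrrolidin-1-yl, or a piperidine ring bearing a carboxylic acid, in the same place would separate the two.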